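Acid and ethyl ester on the shared core

The compounds below may be only part of what the source reports. "The series", "measured", "known", "first", "only" and "open" are said of these compounds alone.

Two compounds of the series carry numbers in a functional assay on the whole organism for inhibition, with Rattus norvegicus as the target, with a stated time of 1 h, at a dose of 100 mg/kg by the oral route; a lower number here means less inhibition, a higher number more inhibition at the dose given (going by the name of the read-out). Compound 1, `O=C(O)C1=C(Nc2ccc(Br)cc2)OCC1=O`, gives 68% in this assay. Among the compounds with values here, compound 2, `O=C(O)C1=C(Nc2cccc(C(F)(F)F)c2)OCC1=O`, gives 54% in this assay, the lower of the two numbers; the only neighbour, compound 1, stands higher by more than the usual scatter. Within the data shown here, no pair among the measured compounds differs in a single place, so no measured step is available.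

Compound 3, `CCOC(=O)C1=C(Nc2cccc(C(F)(F)F)c2)OCC1=O`, differs from compound 2 in one place: ethyl in place of hydrogen on an oxygen next to a carbonyl group. Read one bond further out, carboxy becomes ethoxycarbonyl. Among the measured compounds shown here, nothing among the measured compounds shows how this change moves inhibition in this assay. The expectation is a step from compound 2 of a number 6 percentage points lower from compound 2 to compound 3 (within the scatter), small and not clearly beyond the scatter, with a downward lean. On that basis compound 3 is estimated at 48% in this assay, within a range from 22% to 72%.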

Compound 3, a percentage reported as inhibition, in the whole organism at one dose (the size of the read-out at that dose, not a potency): 40%
Compound 3: middle estimate off by 8 percentage points, on the high side, and the stated range covers the measured number.
By their numbers in this assay, from the lowest: compound 3; then compound 2; then compound 1.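

Ethyl in place of hydrogen on an oxygen next to a carbonyl group, which turns carboxy into ethoxycarbonyl, gives the series its first measured step in this assay: a number 14 percentage points lower from compound 2 to compound 3 (beyond the scatter). The position is therefore not indifferent to this change, and the free carboxy goes with the higher number in this single pair. Inhibition does not vanish with the ethyl group, as compound 3 still gives 40%. No measurement at hand bears on the reason for this step.

One pair cannot show whether the same change would move the number similarly on compound 1. Also open, from the compounds shown here alone, is how a methyl ester, a longer chain such as butyl on the same oxygen, or a primary amide in place of the carboxy would read out at this dose.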